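From sec-butyl to cyclohexyl on the amine nitrogen

This account rests on a few compounds, and the source may have more. Where it says the series, first, only, none or still open, it means among the compounds named here.

Measured in a functional assay on CHO-K1 cells (Cricetulus griseus) for inhibition, read by MTT assay, with a stated time of 72 h (on this read-out higher numbers stand for weaker inhibition and lower numbers for stronger inhibition), each value a limit of the assay and not a number:

Compound 1 `CCCNC(=C\C(=O)/C=C/c1ccc(O)c(OC)c1)/C=C/c1ccc(O)c(OC)c1`: > 25000 nM
Compound 2 `CCC(C)NC(=C\C(=O)/C=C/c1ccc(O)c(OC)c1)/C=C/c1ccc(O)c(OC)c1`: > 25000 nM
Compound 3 `COc1cc(/C=C/C(=O)CC(=O)/C=C/c2ccc(OC(C)=O)c(OC)c2)ccc1OC(C)=O`: > 25000 nM

Compound 2 stands at a limit, > 25000 nM, and has no number of its own. The whole set offers only (the limit of > 25000 nM in this assay, at which 3 of the 3 values shown sit).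

Compound 4 `COc1cc(/C=C/C(=O)/C=C(/C=C/c2ccc(O)c(OC)c2)NC2CCCCC2)ccc1O` departs from compound 2 at one place: cyclohexyl in place of sec-butyl on an amine nitrogen, with cyclohexyl in place of sec-butyl on an amine nitrogen. Within the data shown here, the only measured step that bears on this change is a step that the two limits leave unreadable from compound 1 to compound 2, which also alters the group carried on the amine nitrogen. No size can be carried over from that step, and the data give no direction for the new change.

No step beyond the scatter is expected in this assay, and the likeliest result is that compound 4 again reports only a limit. Among the measured compounds shown here, the estimated change, a step that the limit leaves unreadable from compound 2 to compound 4, is therefore expected to be no real step. Compound 4 is estimated at 30000 nM, with an expected range from 12000 nM to 75000 nM.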

Compound 4, half-maximal inhibitory concentration: 24700 nM
Compound 4: middle estimate off by 1.2-fold (0.08 log units), on the high side, within the range that was stated.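

In this assay, among these compounds, compound 4 gives 24700 nM, a number of its own where the earlier compounds offered none. Cyclohexyl in place of sec-butyl on the amine nitrogen reads as an at least 1.0-fold lower number from compound 2 to compound 4 (0.00 log units; that floor lies within the scatter), and cyclohexyl in place of propyl reads as an at least 1.0-fold lower number from compound 1 to compound 4 (0.00 log units; that floor lies within the scatter), so each step is known only by a floor that lies within the scatter and neither shows a real change. What the result adds is modest: with cyclohexyl on this nitrogen the value can be read as a number, close to the point where the rest of the set stops giving numbers: the limit of > 25000 nM in this assay, at which 3 of the 4 values shown sit.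

The compounds shown leave open how far the true values of compound 1 and compound 2 lie from that of compound 4, and so the real size of both steps stays unknown. Also open, as far as these compounds go, is whether another group on this nitrogen, such as benzyl, cycloheptyl or a longer chain ending in a hydroxyl, would bring the number clearly lower.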